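Methyl on the Phenol Oxygen, Against Thiosulfate Sulfurtransferase

A few compounds are considered here, and "the series" means these few. Any claim that something is new, unique, unknown or untested is made for them only; others in the source may bear on it.

Three amides were examined in an assay on isolated protein for inhibition of thiosulfate sulfurtransferase (Homo sapiens), with a stated time of 60 min, in the absence of a further agent; a higher number here means a weaker inhibitor, a lower number a stronger inhibitor. Compound 3 `O=C(Nc1ccccc1)c1cc(Br)cc(Br)c1O` gives > 100000 nM, which is a limit of the assay and not a number. Compound 1 `COc1c(Br)cc(Br)cc1C(=O)Nc1ccccc1` gives > 100000 nM, again a limit. Compound 2 `O=C(Nc1cccc(Cl)c1)c1ccccc1O` gives > 100000 nM, also a limit. The change from compound 3 to compound 1 is methyl in place of hydrogen on an oxygen on an aromatic ring, and the step that the two limits leave unreadable from compound 3 to compound 1 stays unreadable because of the limit of > 100000 nM in this assay, at which 3 of the 3 values shown sit. The difference between the cores of compound 2 and compound 3 is not broken down here. Compound 4 `COc1ccccc1C(=O)Nc1cccc(Cl)c1` carries the same change on the core of compound 2: methyl in place of hydrogen on an oxygen on an aromatic ring. The step from compound 2 to compound 4 is estimated at a step that the limit leaves unreadable from compound 2 to compound 4, resting on the unreadable step that the two limits leave unreadable from compound 3 to compound 1 and on (the limit of > 100000 nM in this assay, at which 3 of the 3 values shown sit). Compound 4 is therefore expected to give 150000 nM, between 50000 nM and 600000 nM.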

Compound 4, half-maximal inhibitory concentration: > 100000 nM
Compound 4 was reported as a limit; the forecaster's own chance of this, stated with the estimate: 85%; the middle value does not contradict the limit.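

No step can be read from compound 2 to compound 4, because both results are limits of the assay and not numbers: the limit of > 100000 nM in this assay, at which 4 of the 4 values shown sit.

The compounds shown leave open whether changing hydroxy to methoxy alters inhibition at all.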